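Hydroxyethyl Replaces the Oxolane Ring on Compound 2

This account rests on a few compounds, and the source may have more. Where it says the series, first, only, none or still open, it means among the compounds named here.

The measured compounds, each in a functional assay on PC-3M cells (Homo sapiens) for antiproliferative activity, read by microscopy, with a stated time of 24 h; a lower number here means a stronger inhibitor, a higher number a weaker inhibitor:
compound 1, `OCCCNc1ncnc2c1c(-c1ccccc1)c(-c1ccccc1)n2Cc1ccccc1`, gives > 20000 nM, a limit of this assay.
compound 2, `COc1ccc(-c2c(-c3ccc(OC)cc3)n(Cc3ccccc3)c3ncn(CC4CCOC4)c(=N)c23)cc1`, gives > 20000 nM, a limit of this assay.
compound 3, `O[C@H]1CC[C@H](Nc2ncnc3c2c(-c2ccccc2)c(-c2ccccc2)n3Cc2ccccc2)CC1`, gives > 20000 nM, a limit of this assay.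

Compound 2 therefore stands where every measured compound stands: at the limit of > 20000 nM in this assay, at which 3 of the 3 values shown sit. No number separates it from compound 1 or compound 3, and nothing in this assay places it higher or lower than either.

Among the compounds with values here, the only step between measured compounds that differ in one place, a step that the two limits leave unreadable from compound 1 to compound 3, is unreadable, so it offers no size to carry over; it does show that a change of a hydroxy-bearing side chain left both compounds at the limit.

Compound 4, `COc1ccc(-c2c(-c3ccc(OC)cc3)n(Cc3ccccc3)c3ncn(CCCO)c(=N)c23)cc1`, differs from compound 2 by 2-hydroxyethyl in place of oxolan-3-yl on a saturated chain carbon bound to an aromatic nitrogen. This is again a change of a hydroxy-bearing side chain on the same part of the shared core. Since both measured compounds of that kind sit at the limit, the step from compound 2 to compound 4 is expected to be a step that the limit leaves unreadable from compound 2 to compound 4, with no readable direction.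

Compound 4 is therefore estimated at 30000 nM in this assay, within a range from 12000 nM to 100000 nM, most probably reported only as a limit.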

Compound 4, half-maximal inhibitory concentration: > 20000 nM
Compound 4: a limit, no number; the forecaster's own chance of this, stated with the estimate: 85%; the middle value lies beyond the limit too.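

The step from compound 2 to compound 4 cannot be read, as neither compound gives a number and both stand at the same limit: the limit of > 20000 nM in this assay, at which 4 of the 4 values shown sit.

The compounds shown leave open whether any change on the shared core would give a measurable value, and so how 2-hydroxyethyl and oxolan-3-yl compare at this place.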